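This account rests on a few compounds, and the source may have more. Where it says the series, first, only, none or still open, it means among the compounds named here.

In a functional assay on MOLT-4 cells (Homo sapiens) for inhibition (on this read-out higher numbers stand for weaker inhibition and lower numbers for stronger inhibition), compound 1 `COc1cccc(/C=C2\Cc3ccccc3C2=O)c1` gives > 500000 nM, which is a limit of the assay. Compound 2 `O=C1/C(=C/c2ccc(Br)cc2)CCc2ccccc21` gives > 500000 nM, which is also a limit. Among the compounds with values here, compound 3 `O=C1/C(=C/c2cccc(Cl)c2)CCCc2ccccc21` gives 23800 nM, the only actual number in this small set, so it is the single firm reference point in this assay.

Compound 4 `Cc1cccc(/C=C2\CCCc3ccccc3C2=O)c1` keeps the core of compound 3 and changes one substituent: methyl in place of chloro on an aromatic carbon. In words, this is methyl in place of chloro on an aromatic carbon, meta to a large group. Within the data shown here, no measured pair in the set isolates this swap, and the data do not show directly how a chloro or a methyl at this place affects inhibition.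

The expectation therefore starts from compound 3 at 23800 nM and allows for a modest loss of inhibition, not a large change in either direction. The estimated change is a 2.5-fold higher number from compound 3 to compound 4 (0.40 log units; beyond the scatter), a moderate step towards weaker inhibition with wide uncertainty. For compound 4, the expected value is 60000 nM, with an estimated range of 15000 nM to 250000 nM.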

Compound 4, half-maximal inhibitory concentration: 34600 nM
Compound 4: middle estimate off by 1.7-fold (0.24 log units), on the high side, and the stated range covers the measured number.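

In this assay, methyl in place of chloro on an aromatic carbon, meta to a large group, gives a 1.5-fold higher number from compound 3 to compound 4 (0.16 log units; within the scatter). Within the data shown here, this is the first pair in the set that differs in one place only, and it shows that on the core of compound 3 this swap does not move the read-out beyond the usual scatter, so chloro and methyl cannot be told apart at this position. Steps to compound 1 and compound 2 cannot be read, as they differ from the others in more than one place and each gives only a limit of the assay: the limit of > 500000 nM in this assay, at which 2 of the 4 values shown sit.

Among these compounds, whether an amine, a carboxylic acid or a longer chain at this place would shift the number beyond the scatter remains open, since chloro and methyl are the only two groups compared here. Going by these compounds, it is also open whether chloro and methyl would match in the same way on the cores of compound 1 and compound 2.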